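The source may hold more compounds than are shown below. What is called first, only, known or untested is meant among the compounds shown, and "the series" means these compounds.

Compounds measured in an assay on isolated protein for binding affinity to Leucine-rich repeat serine/threonine-protein kinase 2 (Homo sapiens), read by TR-FRET and LanthaScreen, with a stated time of 2 h; a lower number here means a stronger inhibitor, a higher number a weaker inhibitor:
compound 1, `Cc1n[nH]cc1Nc1nc(N)c2c(C#N)c(N3CCC[C@H]3C)n(C)c2n1`, gives 1 nM
compound 2, `C[C@@H]1CCCN1c1c(C#N)c2c(N)nc(N)nc2n1C`, gives 6 nM
compound 3, `C[C@@H]1CCCN1c1c(C#N)c2c(N)ncnc2n1C`, gives 0.4 nM

Compound 3 stands at the lowest of the three numbers in this assay. Its nearest neighbour is compound 1, separated by a 2.5-fold lower number from compound 1 to compound 3 (0.40 log units; beyond the scatter), and its furthest is compound 2, separated by a 15-fold lower number from compound 2 to compound 3 (1.18 log units; beyond the scatter). Compound 4, `C[C@@H]1CCCN1c1c(C#N)c2c(N)nc(Nc3cnn(C)c3)nc2n1C`, differs from compound 3 in one place: (1-methyl-1H-pyrazol-4-yl)amino in place of hydrogen on an aromatic carbon. Going by the values given here, two measured steps bear on this change. The step of a 2.5-fold lower number from compound 1 to compound 3 (0.40 log units; beyond the scatter) is the reverse of a closely related change, so putting such a group back onto compound 3 is expected to cost a modest amount. The step of a 6.0-fold higher number from compound 1 to compound 2 (0.78 log units; beyond the scatter) shows that the pyrazolyl part of that group matters, and a 15-fold lower number from compound 2 to compound 3 (1.18 log units; beyond the scatter) shows that a bare amino alone is costly. A modest upward step a 2.5-fold higher number from compound 3 to compound 4 (0.40 log units; beyond the scatter) is therefore expected. Compound 4 is expected to give about 1 nM in this assay, within roughly 0.4 nM to 3 nM.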

Compound 4, inhibition constant: 0.1 nM
Beside the measured number, compound 4's estimate is 10-fold (1.00 log units) above it; measured number outside the range, below it.
By their numbers in this assay, from the lowest: compound 4; then compound 3; then compound 1; then compound 2.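

In this assay, the aromatic carbon between two ring nitrogen atoms can gain from a substituent as well as lose: the new group gives a 4.0-fold lower number from compound 3 to compound 4 (0.60 log units; beyond the scatter), whereas (3-methyl-1H-pyrazol-4-yl)amino stood on the weaker side of a 2.5-fold lower number from compound 1 to compound 3 (0.40 log units; beyond the scatter). The direction of the change therefore depends on the pyrazole, since 1-methyl-1H-pyrazol-4-yl in place of 3-methyl-1H-pyrazol-4-yl gives a 10-fold lower number from compound 1 to compound 4 (1.00 log units; beyond the scatter). On the bare amino group, the same 1-methyl-1H-pyrazol-4-yl gives a 60-fold lower number from compound 2 to compound 4 (1.78 log units; beyond the scatter), the largest step in this set.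

Nothing available here explains these steps. Going by these compounds, it remains open whether the gain is tied to the methyl on the pyrazole nitrogen or would persist with an ethyl group there, or with a phenyl ring in place of the pyrazole.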